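The source may hold more compounds than are shown below. What is called first, only, known or untested is meant among the compounds shown, and "the series" means these compounds.

In a functional assay on HepG2 cells (Homo sapiens) for cytotoxicity, read by MTT assay, with a stated time of 24 h (a lower number here means a stronger inhibitor, a higher number a weaker inhibitor), compound 1 (`O=C1/C(=C/c2cccnc2)CN(S(=O)(=O)c2ccc([N+](=O)[O-])cc2)C/C1=C\c1ccccc1F`) gives 12800 nM. Compound 2 (`O=C1/C(=C/c2cccnc2)CN(S(=O)(=O)c2ccc([N+](=O)[O-])cc2)C/C1=C\c1ccccc1C(F)(F)F`) gives 9370 nM, which is level with compound 1 within the scatter. Compound 3 (`O=C1/C(=C/c2cccnc2)CN(S(=O)(=O)c2ccc(Br)cc2)C/C1=C\c1ccccc1C(F)(F)F`) differs from compound 2 in one place: bromo in place of nitro on an aromatic carbon. This is bromo in place of nitro on an aromatic carbon, turning 4-nitrophenyl into 4-bromophenyl. Going by the values given here, no measured pair tests a change at this place. Among the compounds with values here, the only measured step, a 1.4-fold lower number from compound 1 to compound 2 (0.14 log units; within the scatter), is trifluoromethyl in place of fluoro elsewhere in the molecule. It bears only indirectly and gives no direction for the present change, so no step beyond the scatter is expected in this assay. The estimate corresponds to an expected 1.1-fold higher number from compound 2 to compound 3 (0.03 log units; within the scatter). Compound 3 is estimated at 10000 nM, with an expected range of 4000 nM to 25000 nM.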

Compound 3, half-maximal inhibitory concentration: 2730 nM
Beside the measured number, compound 3's estimate is 3.7-fold (0.56 log units) above it; measured number below the stated range.
By their numbers in this assay, from the lowest: compound 3; then compounds 2 and 1 (each within the scatter of the next).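

In this assay, bromo in place of nitro on this aromatic carbon gives a step beyond the scatter (a 3.4-fold lower number from compound 2 to compound 3 (0.54 log units; beyond the scatter)), so the 4-nitrophenyl to 4-bromophenyl change moves the number here. Going by these compounds alone, the only earlier step, trifluoromethyl in place of fluoro elsewhere in the molecule (a 1.4-fold lower number from compound 1 to compound 2 (0.14 log units; within the scatter)), stayed within the scatter and said nothing about this position. No measurement shown accounts for the size or direction of the new step.

With only nitro and bromo compared at this position, the compounds shown do not tell whether an amine, a carboxylic acid or a methoxy group there would fall with either of them in this assay. Going by these compounds, it also remains open whether the same change gives a similar step when fluoro replaces trifluoromethyl, as in compound 1.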